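This account rests on a few compounds, and the source may have more. Where it says the series, first, only, none or still open, it means among the compounds named here.

Measured compounds:
- compound 1, `CCOC(=O)c1cnn(-c2nc(-c3ccc(Cl)cc3)c(C#N)c(=O)n2C)c1N`: 87 ug/mL
- compound 2, `CSc1nc(-c2cccc(O)c2O)c(C#N)c(=O)n1C`: 53 ug/mL
- compound 3, `COc1ccc(-c2nc(NN)n(C)c(=O)c2C#N)cc1`: 56 ug/mL

The three compounds were tested in a functional assay, with a stated time of 150 min; a lower number here means a stronger inhibitor, a higher number a weaker inhibitor. Compound 1 gives 87 ug/mL, compound 3 gives 56 ug/mL and compound 2 gives 53 ug/mL. All three numbers sit within the usual scatter of one another, so compound 1 is not separated from either of the others; the three behave alike in this assay, and none can be called more or less potent.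

Compound 4, `CCOC(=O)c1cnn(-c2nc(-c3ccc(N(C)C)cc3)c(C#N)c(=O)n2C)c1N`, is not yet measured. It differs from compound 1 in one place: dimethylamino in place of chloro on an aromatic carbon. The change sits on an aromatic carbon of a six-membered aromatic ring of carbon only, para to a large group.

Among the compounds with values here, no measured pair in this set shows what such a change does, so the step is not known from the data. Within the data shown here, compound 4 is therefore expected to land close to compound 1, with no step in this assay clearly beyond the scatter, and the expected step from compound 1 to compound 4 is a 1.2-fold lower number from compound 1 to compound 4 (0.06 log units; within the scatter). For compound 4 the estimated value is 75 ug/mL, with a range from 30 ug/mL to 180 ug/mL.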

Compound 4, half-maximal inhibitory concentration: 115 ug/mL
For compound 4 the middle estimate is 1.5-fold (0.19 log units) below the measured one; measured number inside the range.
By their numbers in this assay, from the lowest: compounds 2, 3, 1 and 4 (each within the scatter of the next, the first and the last beyond it).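

Within the data shown here, compounds 1 and 4 are the only pair here that differs in one place, so they give a direct reading of a change on this aromatic carbon, para to a large group. Dimethylamino in place of chloro gives a 1.3-fold higher number from compound 1 to compound 4 (0.12 log units; within the scatter) in this assay, so replacing the single chlorine atom with this group of three heavy atoms leaves no step that can be told from repeat-measurement noise at this position. Nothing measured here offers a reason for this result.

This single pair cannot show whether this position stays as undemanding for very different groups, such as a carboxylic acid or a morpholine ring. It also leaves open whether the same change would give a similar step on the cores of the other compounds.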